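Amino substitution on the purine-type core and growth inhibition

The source may report more compounds than this note shows. Statements on the series, on what has been measured and on what is new or still open speak of the compounds shown alone.

Three compounds share a chloro-bearing fused two-ring core carrying a benzyl group with a chloromethyl arm. Compound 1 `ClCc1ccc(Cn2cnc3c(Cl)ncnc32)cc1`, compound 2 `Nc1nc(Cl)c2ncn(Cc3ccc(CCl)cc3)c2n1` and compound 3 `ClCc1ccccc1Cn1cnc2c(Cl)ncnc21` have been measured in a functional assay on ACHN cells (Homo sapiens) for cytotoxicity, read by sulforhodamine B assay, with a stated time of 48 h; on this read-out higher numbers stand for weaker inhibition of growth and lower numbers for stronger inhibition of growth. In this assay compound 1 gives 1280 nM, compound 2 gives 25100 nM and compound 3 gives 6160 nM. Compound 3 stands second highest of the three, with compound 1 giving a lower number and compound 2 a higher one; the difference between the cores of compound 1 and compound 3 is not broken down here.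

Within the data shown here, the one counted change is amino in place of hydrogen on an aromatic carbon, which gave a 20-fold higher number from compound 1 to compound 2 (1.29 log units; beyond the scatter). The same change is now proposed from compound 3 to the unmeasured compound 4 `Nc1nc(Cl)c2ncn(Cc3ccccc3CCl)c2n1`, described as amino in place of hydrogen on an aromatic carbon. Among the measured compounds shown here, the surroundings of the place are the same in both pairs, so the expectation rests directly on the single measured instance. For compound 4 a step of a 16-fold higher number from compound 3 to compound 4 (1.21 log units; beyond the scatter) is expected, because the same change from compound 1 to compound 2 gave a 20-fold higher number from compound 1 to compound 2 (1.29 log units; beyond the scatter) and compound 3 already starts from the higher value of 6160 nM. Compound 4 is therefore estimated at 100000 nM in this assay, with a range from 25000 nM to 300000 nM, and with one measured example only the width of this range is wide; a result reported only as a limit cannot be excluded at such a weak level of growth inhibition.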

Compound 4, concentration for total growth inhibition: 21900 nM
Estimate against measurement, compound 4: 4.6-fold (0.66 log units) above; the measured number lies below the stated range.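

In this assay the amino change points the same way on the second core, giving a 3.6-fold higher number from compound 3 to compound 4 (0.55 log units; beyond the scatter) and so matching the direction of the earlier pair. The size of the step does not carry over, and the two steps differ by more than the scatter of such steps: the same change on two cores in this assay, a 20-fold higher number (1.29 log units; beyond the scatter) from compound 1 to compound 2 and a 3.6-fold higher number (0.55 log units; beyond the scatter) from compound 3 to compound 4, 5.5-fold (0.74 log units) apart, beyond the scatter of two such steps. The step measured on one core therefore gave the direction on the other but not a usable magnitude, and two pairs show neither what in the cores sets the size of the step nor whether the direction would hold on any further core.

The compounds shown carry only the amino group at this place, so it remains open whether a methylamino group, a hydroxyl group or a methoxy group in place of the hydrogen would move the number in the same direction. Also open, going by these compounds, is how the step would behave with the chloromethyl arm exchanged for a methyl group or a longer chain such as chloroethyl, or with the chloro group on the core exchanged for a methoxy group.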